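This account rests on a few compounds, and the source may have more. Where it says the series, first, only, none or still open, it means among the compounds named here.

Measured compounds:
compound 1 `Cn1c(=O)c2[nH]c(-c3ccc(OCCCCl)cc3)nc2n(C)c1=O`, > 10 nM
compound 2 `Cn1c(=O)c2[nH]c(-c3ccc(OC4CCCC4)cc3)nc2n(C)c1=O`, > 30 nM

In an assay on CHO cells for displacement of a labelled ligand from adenosine receptor A1 (Homo sapiens), read by scintillation counting, with a stated time of 3 h (a lower number here means a stronger inhibitor, a higher number a weaker inhibitor), compound 1 gives > 10 nM, which is a limit of the assay rather than a number. In this assay compound 2 gives > 30 nM, likewise a limit of the assay and not a number. The step that the two limits leave unreadable from compound 1 to compound 2 therefore cannot be read; the two limits the limit of > 10 nM in this assay, at which 1 of the 2 values shown sits, and the limit of > 30 nM in this assay, at which 1 of the 2 values shown sits, are all the evidence there is, and neither fixes where compound 2 truly stands. Compound 3 `Cn1c(=O)c2[nH]c(-c3ccc(OCCCn4ccnc4)cc3)nc2n(C)c1=O` differs from compound 2 by 3-(1H-imidazol-1-yl)propyl in place of cyclopentyl on an oxygen on an aromatic ring. For the measured compounds named here, no measured step bears on this exchange, so no size or direction can be drawn from the data. The estimate for compound 3 in this assay is 60 nM, within 8 nM to 500 nM. This estimate means a step that the limit leaves unreadable from compound 2 to compound 3 from compound 2, and it is likely that only a limit will be reported again.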

Compound 3, inhibition constant: 0.89 nM
Estimate against measurement, compound 3: 67-fold (1.83 log units) above, outside the stated range (below it).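

In this assay, for the compounds shown here, 3-(1H-imidazol-1-yl)propyl in place of cyclopentyl on the oxygen gives an at least 33-fold lower number from compound 2 to compound 3 (1.52 log units; beyond the scatter), and compound 3 is the only one of the three compounds with a true number rather than a limit. With the propyl chain kept, 1H-imidazol-1-yl in place of chloro gives an at least 11-fold lower number from compound 1 to compound 3 (1.05 log units; beyond the scatter), so at this position the propyl chain alone does not account for the change, and what sits at its end matters. The data shown give no reason why the imidazole has this effect.

A dimethylamino group or a phenyl ring at the end of the chain would show whether the imidazole itself is needed. A butyl chain carrying the same imidazole would show whether the length of the chain counts as well.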